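The source may hold more compounds than are shown below. What is called first, only, known or untested is meant among the compounds shown, and "the series" means these compounds.

Compound 2 `Cc1c(C(=O)Nc2c(F)cc(-c3cccc(F)c3)cc2F)nc2ccc(F)cc2c1O` stands level with compound 1 `CCc1ccc2nc(C(=O)Nc3c(F)cc(-c4cccc(F)c4)cc3F)c(C)c(O)c2c1`, the two together giving the highest numbers of the three measured, while compound 3 `Cc1c(C(=O)Nc2c(F)cc(-c3cccc(F)c3)cc2F)nc2ccc(OC(F)(F)F)cc2c1O` lies close by. In a functional assay on A-375 cells (Homo sapiens) for antiproliferative activity, read by MTT assay, with a stated time of 24 h, tested at 0.01 ug/mL (on this read-out higher numbers stand for a stronger effect at the one concentration tested and lower numbers for a weaker effect), compound 2 gives -0.35%, compound 1 gives -0.35% and compound 3 gives -0.68%. Compound 4 `Cc1c(C(=O)Nc2c(F)cc(-c3cccc(F)c3)cc2F)nc2ccc(C(F)(F)F)cc2c1O` differs from compound 2 by trifluoromethyl in place of fluoro on an aromatic carbon. The measured step that bears most on this change is a number 0.3 percentage points lower from compound 2 to compound 3 (within the scatter); the other two, no change at the digits printed from compound 1 to compound 2 (within the scatter) and a number 0.3 percentage points lower from compound 1 to compound 3 (within the scatter), are equally flat. Nothing among these steps points to movement beyond the scatter in this assay, so no step beyond it is expected. Compound 4 is therefore estimated at -0.4%, between -6% and 5%. This amounts to an expected a number 0.1 percentage points lower from compound 2 to compound 4 (within the scatter).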

Compound 4, a percentage reported as inhibition, at one concentration (the size of the read-out at that concentration, not a potency): 0.16%
Beside the measured number, compound 4's estimate is 0.6 percentage points below it; the range from low to high includes it.
By their numbers in this assay, from the lowest: compounds 3, 1, 2 and 4 (each within the scatter of the next).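

At this aromatic carbon of the shared core, trifluoromethyl, with its 4 heavy atoms against 1 for fluoro, leaves the read-out in this assay unmoved: the result is a number 0.5 percentage points higher from compound 2 to compound 4 (within the scatter), with a number 0.5 percentage points higher from compound 1 to compound 4 (within the scatter) and a number 0.8 percentage points higher from compound 3 to compound 4 (within the scatter). All four substituents now sit within the scatter of one another, so this larger replacement opens no separation at this position. No measurement shown gives any explanation for this result.

As far as these compounds go, whether an amine, a carboxylic acid or a longer chain at this carbon would move the number remains open. So does whether these compounds would separate at a higher concentration.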